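Ester variation in a chromone vinyl sulfoxide series

The source may hold more compounds than are shown below. What is called first, only, known or untested is meant among the compounds shown, and "the series" means these compounds.

Measured compounds and their values:
- compound 1, `COc1ccc2c(=O)cc(/C=C/[S+](C)[O-])oc2c1`: 7800 nM
- compound 2, `CCCCC(=O)Oc1ccc2oc(/C=C/[S+](C)[O-])cc(=O)c2c1`: 6700 nM
- compound 3, `COc1cccc2c(=O)cc(/C=C/[S+](C)[O-])oc12`: 9000 nM

All three were run in a functional assay on DLD-1 cells (Homo sapiens) for cytotoxicity, with a stated time of 48 h; a lower number here means a stronger inhibitor, a higher number a weaker inhibitor. Compound 1 gives 7800 nM, compound 3 gives 9000 nM, and compound 2 gives 6700 nM. Compound 2 holds the lowest of the three numbers, but its gaps to compound 1 and to compound 3 both sit inside the usual scatter of this assay, so no order among the three can be read from these values.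

The next compound, compound 4, `C[S+]([O-])/C=C/c1cc(=O)c2cc(OC(=O)C(C)(C)C)ccc2o1`, is not yet measured. It is built from compound 2 with one change: tert-butyl in place of butyl on a carbonyl carbon. The same atoms are present, joined differently, and the count of donors, acceptors and ring atoms is unchanged.

For the measured compounds named here, no step between two measured compounds is available for this kind of change, so there is nothing to point in either direction. The expectation for compound 4 in this assay is therefore a step from compound 2 that stays within the scatter, a 1.0-fold higher number from compound 2 to compound 4 (0.02 log units; within the scatter). Compound 4 is estimated at 7000 nM, with a range from 3500 nM to 14000 nM.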

Compound 4, half-maximal inhibitory concentration: 8000 nM
The estimate for compound 4 lay 1.1-fold (0.06 log units) below the measured number; low and high end bracket the measured number.
By their numbers in this assay, from the lowest: compounds 2, 1, 4 and 3 (each within the scatter of the next).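

In this assay, for the compounds shown here, tert-butyl in place of butyl on a carbonyl carbon gives a 1.2-fold higher number from compound 2 to compound 4 (0.08 log units; within the scatter), the first step in this set between two compounds that differ in one place. At this position, then, rejoining the same atoms of the ester chain does not move the number beyond the scatter, and compound 2 and compound 4 cannot be told apart on these values. No measured evidence bears on this result, so the flat step stands as an observation without an explanation.

Only these two arrangements of the acyl chain can be compared, so the flat step says nothing about how far this position stays insensitive to change. A longer chain such as octanoyl, a benzoyl ester, a free hydroxyl in place of the ester, or an amide or carbamate linkage at the same place would test whether the number responds to the group here at all, or whether the ester chain remains without a readable effect across a wider range of groups.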